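Methyl for methoxy on the fused ring of compound 1

The source may report more compounds than this note shows. Statements on the series, on what has been measured and on what is new or still open speak of the compounds shown alone.

Measured so far:
compound 1 `COc1cccc2c1OCN(c1ccc3oc(-c4ccccc4)cc(=O)c3c1)C2` — 54%
compound 2 `Cc1cc(C)c2c(c1)CN(c1ccc3c(=O)cc(-c4ccccc4)oc3c1)CO2` — "not active" (no number reported)
compound 3 `O=c1cc(-c2ccccc2)oc2ccc(N3COc4c(Br)cc(Br)cc4C3)cc12` — 13.6%

Three compounds share the core and differ only in the substituents on the fused benzo ring. In a functional assay on MCF7 cells (Homo sapiens) for inhibition, read by MTT assay, with a stated time of 48 h, tested at 15 ug/mL (on this read-out higher numbers stand for more inhibition of growth at the one concentration tested and lower numbers for less inhibition of growth), compound 1 gives 54%. Compound 3, carrying two bromines on that ring, gives 13.6%, a number that lies well beyond the scatter below compound 1. For compound 2, with two methyls, the read is "not active" (no number reported) and no number is reported, so it cannot be placed on the same scale. Of the two numbers available, compound 1 is the higher. The gap to compound 3 lies beyond the scatter.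

The next compound, compound 4 `Cc1cccc2c1OCN(c1ccc3oc(-c4ccccc4)cc(=O)c3c1)C2`, keeps everything of compound 1 except for one change: methyl in place of methoxy on an aromatic carbon. For the measured compounds named here, no pair of measured compounds isolates this change, so its size must be guessed from the series as a whole, where every departure from the methoxy-bearing ring has so far given a weaker or absent response. A downward step of moderate size is expected, around a number 19 percentage points lower from compound 1 to compound 4 (beyond the scatter), possibly just beyond the scatter. Compound 4 is accordingly estimated at 35%, with a plausible range from 10% to 60%.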

Compound 4, percent growth inhibition at one concentration: 60.9%
Compound 4: the middle estimate sits 25.9 percentage points below what was measured, outside the stated range (above it).
By their numbers in this assay, from the lowest: compound 3; then compounds 1 and 4 (each within the scatter of the next).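

In this assay, methyl in place of methoxy on an aromatic carbon of the fused ring gives a number 6.9 percentage points higher from compound 1 to compound 4 (within the scatter), so this read-out does not separate the two groups at this position. For the compounds shown here, the methoxy, with its oxygen and its hydrogen-bond acceptor, is therefore not needed here for inhibition of growth at the one concentration tested, a point that the earlier compounds, each differing from compound 1 in more than one place, could not show on their own. Nothing at hand bears on why this exchange leaves the read-out within the usual scatter.

Open, from the compounds shown here alone, is whether this position accepts groups of a different kind, such as an amine, a carboxylic acid or a longer chain like propyl, or whether the response holds with only a hydrogen on that carbon. Going by these compounds alone, also open is whether compound 1 and compound 4 stay together at other concentrations, since a single-concentration read-out gives no curve for either compound.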